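From Cyclobutyloxy to Isopropylsulfanyl on the Carbonyl Carbon

The compounds below may be only part of what the source reports. "The series", "measured", "known", "first", "only" and "open" are said of these compounds alone.

Compound 1, `Cc1nc(S(C)(=O)=O)ccc1Oc1ncnc(OC2CCN(C(=O)OC3CCC3)CC2)c1F`, 81%
Compound 2, `Cc1nc(S(C)(=O)=O)ccc1Oc1ncnc(OC2CCN(C(=O)O[C@H](C)CF)CC2)c1F`, 79%

In a functional assay on isolated protein for inhibition of Glucose-dependent insulinotropic receptor (Rattus norvegicus), read by HTRF and cAMP accumulation (a higher number here means a larger maximal response, a lower number a smaller maximal response), compound 1 gives 81%. Compound 2 gives 79%, and the step of a number 2 percentage points lower from compound 1 to compound 2 (within the scatter) is within the scatter, so the two measured compounds cannot be told apart on these numbers; compound 1 stands simply as one of two equivalent values. Compound 3, `Cc1nc(S(C)(=O)=O)ccc1Oc1ncnc(OC2CCN(C(=O)SC(C)C)CC2)c1F`, differs from compound 1 by isopropylsulfanyl in place of cyclobutyloxy on a carbonyl carbon. For the measured compounds named here, the only measured step, from compound 1 to compound 2, exchanged one group for another on the oxygen next to the carbonyl and left the read-out essentially unchanged. Going by the values given here, the change to compound 3 goes further, replacing the cyclobutyloxy with isopropylsulfanyl, and no measured pair covers an exchange of this kind. Among the compounds with values here, with one small step as the sole guide, the expectation is a step of no more than the scatter, perhaps a slight lowering. The expected step is a number 6 percentage points lower from compound 1 to compound 3 (within the scatter). Compound 3 is therefore estimated to give 75%, within a range from 62% to 88%.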

Compound 3, largest response reached (reported as efficacy), in percent of the reference or control that the assay uses: 81%
Compound 3: middle estimate off by 6 percentage points, on the low side, within the range that was stated.
By their numbers in this assay, from the lowest: compounds 2, 1 and 3 (each within the scatter of the next).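

For the compounds shown here, the step to compound 3 is the first at this position to alter the atom bonded to the carbonyl carbon, with sulfur in place of oxygen, and it also removes the four-membered ring: in this assay the exchange of cyclobutyloxy for isopropylsulfanyl gives no change at the digits printed from compound 1 to compound 3 (within the scatter). The comparison with the open-chain fluorinated group reads a number 2 percentage points higher from compound 2 to compound 3 (within the scatter), so among these three compounds, neither the ring nor the oxygen on the carbonyl carbon is needed for a maximal response that cannot be told apart from that of compound 1. No measurement given here explains why the three compounds read alike.

Because the ring and the linking atom change together from compound 1 to compound 3, the compounds shown do not separate the two changes, and a cyclobutylsulfanyl group on the same carbonyl carbon would be the direct link between them. They also leave open whether this tolerance extends beyond oxygen and sulfur links to an amine such as isopropylamino, or to a longer chain such as n-hexylsulfanyl.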